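The source may report more compounds than this note shows. Statements on the series, on what has been measured and on what is new or still open speak of the compounds shown alone.

Three compounds have been measured in a functional assay on HCT-116 cells (Homo sapiens) for antiproliferative activity, read by MTT assay; a higher number here means a weaker inhibitor, a lower number a stronger inhibitor:
compound 1, `Cn1c(=O)c(=O)n(C2CCCC2)c2nc(N/N=C/c3ccc(F)cc3Cl)ncc21`, with 13800 nM;
compound 2, `Cn1c(=O)c(=O)n(C2CCCC2)c2nc(N/N=C/c3cc(C(F)(F)F)cc(C(F)(F)F)c3)ncc21`, with 4360 nM;
compound 3, `COc1cc(/C=N/Nc2ncc3c(n2)n(C2CCCC2)c(=O)c(=O)n3C)cc(OC)c1OC`, with 22900 nM.

All three share the same core and differ only in the substituted aromatic ring carried at one end of it. Compound 1 stands second highest of the three numbers. Its nearest neighbour is compound 3, whose number lies within the usual scatter of that of compound 1, so the two cannot be told apart. Compound 2 gives a number that is lower than that of compound 1 by more than the scatter, so of this pair compound 2 is the stronger inhibitor.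

Compound 4, `Cn1c(=O)c(=O)n(C2CCCC2)c2nc(N/N=C/c3ccc(F)cc3F)ncc21`, has not yet been measured. It differs from compound 1 in one place: fluoro in place of chloro on an aromatic carbon. Going by the values given here, no measured pair shows the effect of this exchange; the measured compounds vary the aromatic ring in larger ways. An exchange of one halogen for another gives little reason to expect a shift beyond the scatter in either direction. Compound 4 is therefore expected to land close to compound 1, with an estimated step of a 1.1-fold higher number from compound 1 to compound 4 (0.04 log units; within the scatter). The estimate for compound 4 in this assay is 15000 nM, with a range from 6000 nM to 38000 nM.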

Compound 4, half-maximal inhibitory concentration: 19800 nM
Compound 4: middle estimate off by 1.3-fold (0.12 log units), on the low side, and the stated range covers the measured number.
By their numbers in this assay, from the lowest: compound 2; then compounds 1, 4 and 3 (each within the scatter of the next).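

In this assay the exchange of fluoro for chloro, on the aromatic carbon ortho to a large group, gives a 1.4-fold higher number from compound 1 to compound 4 (0.16 log units; within the scatter) and so the 2-chloro-4-fluorophenyl and 2,4-difluorophenyl versions cannot be told apart. This is the first pair among the compounds shown that differs in one place only, and it gives a direct reading that the earlier compounds, which vary the aromatic ring in larger ways, could not give: at this position, one of these halogens can stand in for the other with no shift that rises above the scatter. Nothing available explains why this exchange behaves as it does.

The compounds shown compare only chloro and fluoro at this position, so it remains open whether a group of another kind there, such as an amine, a hydroxyl or a carboxylic acid, would move the number beyond the scatter. Going by these compounds, this single pair also reads the exchange only with a fluoro group meta to the changed carbon, so it remains open whether the same exchange would give a similar result with a different group in that place.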